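Removing a Fluorine from the Ring on the Sulfonyl Sulfur

The source may report more compounds than this note shows. Statements on the series, on what has been measured and on what is new or still open speak of the compounds shown alone.

Compound 1 `CCCCC(CC)C(=O)Nc1ccc2ccn(Cc3ccc(C(=O)NS(=O)(=O)c4ccc(F)cc4)cc3OC)c2c1` is one of three compounds built on a shared core and tested in a functional assay (trachea) for antagonist activity, with Cavia porcellus as the target (a higher number here means a more potent compound, by a factor of ten per unit of this negative logarithm, a lower number a less potent compound), where compound 1 gives 7.7. This is the lowest of the three numbers measured: compound 2 `COc1cc(C(=O)NS(=O)(=O)c2cccs2)ccc1Cn1ccc2ccc(NC(=O)CC3CCCC3)cc21` gives 9.6, and compound 3 `COc1cc(C(=O)NS(=O)(=O)c2c(C)cccc2Cl)ccc1Cn1ccc2ccc(NC(=O)CC3CCCC3)cc21` gives 8.8. Going by the values given here, the only measured step that alters a single place is a number 0.80 log units lower from compound 2 to compound 3 (beyond the scatter); it exchanges the whole aromatic group attached to the sulfonyl sulfur, and its size is modest.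

Compound 4 `CCCCC(CC)C(=O)Nc1ccc2ccn(Cc3ccc(C(=O)NS(=O)(=O)c4ccccc4)cc3OC)c2c1` differs from compound 1 in a far smaller way: hydrogen in place of fluoro on an aromatic carbon. Among the compounds with values here, no measured pair shows this exact change, so the one measured step can serve only as a rough outer bound: if swapping the entire group on the sulfonyl sulfur moved the read-out modestly, the loss of a single fluorine from that ring is expected to move it less, with no clear direction suggested by the data. The expected step is no change at the digits printed from compound 1 to compound 4 (within the scatter), which is meant as no change beyond the scatter. Compound 4 is therefore estimated at 7.7, with a range from 7.2 to 8.2.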

Compound 4, negative logarithm of the antagonist equilibrium constant: 8.6
Beside the measured number, compound 4's estimate is 0.90 log units below it; the measured number lies above the stated range.
By their numbers in this assay, from the lowest: compound 1; then compounds 4 and 3 (each within the scatter of the next); then compound 2.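

In this assay, a number 0.90 log units higher from compound 1 to compound 4 (beyond the scatter), which shows that this place on the ring carried by the sulfonyl sulfur is not a silent one: exchanging a single fluoro for hydrogen is enough to move the read-out beyond the scatter. Going by these compounds alone, until now, the only step read at the sulfonyl sulfur was a number 0.80 log units lower from compound 2 to compound 3 (beyond the scatter), which exchanged the whole aromatic group, so it could not show what one atom on that ring contributes. Here the direction is clear for this one pair, with the higher number belonging to the phenyl compound rather than the 4-fluorophenyl compound, but nothing measured here accounts for the step.

The compounds shown do not tell how chloro, methyl, an amine or a carboxylic acid at this same place would compare with hydrogen or fluoro. Within the data shown here, whether removing the fluoro would give a similar step with a different group elsewhere on the shared core also stays open, as this change is seen in only one pair.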